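The source may hold more compounds than are shown below. What is called first, only, known or untested is meant among the compounds shown, and "the series" means these compounds.

Measured compounds:
- compound 1 `CC(=O)Oc1ccc2oc(/C=C/[S+](C)[O-])cc(=O)c2c1`: 4100 nM
- compound 2 `CC(C)CCOc1ccc2oc(/C=C/[S+](C)[O-])cc(=O)c2c1`: 1000 nM
- compound 3 `C[S+]([O-])/C=C/c1cc(=O)c2cc(Cl)ccc2o1`: 1700 nM

In a functional assay on A549 cells (Homo sapiens) for cytotoxicity, with a stated time of 48 h (a higher number here means a weaker inhibitor, a lower number a stronger inhibitor), compound 3 gives 1700 nM. The smaller of its two measured steps is a 1.7-fold higher number from compound 2 to compound 3 (0.23 log units; within the scatter), which stays within the scatter. The larger is a 2.4-fold lower number from compound 1 to compound 3 (0.38 log units; beyond the scatter), which lies beyond the scatter but remains modest.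

Compound 4 `C[S+]([O-])/C=C/c1cc(=O)c2cc(Br)ccc2o1` carries one change: bromo in place of chloro on an aromatic carbon. The series holds no measured swap of one halogen for another, so the evidence is indirect. Among the compounds with values here, the steps that bear on it exchange chloro for acetoxy or isopentyloxy, and the largest step, a 4.1-fold lower number from compound 1 to compound 2 (0.61 log units; beyond the scatter), is still modest. A swap of chloro for bromo is therefore expected to give no step beyond the scatter, and no direction is favoured.

The expected change is a 1.1-fold lower number from compound 3 to compound 4 (0.05 log units; within the scatter), which is estimated to stay within the scatter. Compound 4 is estimated at 1500 nM, with an expected range of 750 nM to 3000 nM.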

Compound 4, half-maximal inhibitory concentration: 1100 nM
Estimate against measurement, compound 4: 1.4-fold (0.13 log units) above, and the stated range covers the measured number.
By their numbers in this assay, from the lowest: compounds 2, 4 and 3 (each within the scatter of the next); then compound 1.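

In this assay the exchange of one halogen for another on this aromatic carbon now has a direct reading, and the step stays within the scatter, so chloro and bromo cannot be told apart here (a 1.5-fold lower number from compound 3 to compound 4 (0.19 log units; within the scatter)). Bromo also cannot be told apart from isopentyloxy (a 1.1-fold higher number from compound 2 to compound 4 (0.04 log units; within the scatter)), whereas the step from acetoxy lies beyond the scatter but remains modest (a 3.7-fold lower number from compound 1 to compound 4 (0.57 log units; beyond the scatter)), so among the groups shown at this carbon, only acetoxy stands apart. No measurement at hand bears on the reason for these readings.

From the compounds shown here alone, whether this narrow spread extends to fluoro, iodo, an amine or a carboxylic acid on the same carbon remains open. A longer alkoxy chain would show whether isopentyloxy is typical of ether groups at this position.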